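Aryl versus alkyl on the fused core: compound 4

A few compounds are considered here, and "the series" means these few. Any claim that something is new, unique, unknown or untested is made for them only; others in the source may bear on it.

Measured compounds in a functional assay on cells (Lymphocyte, Homo sapiens); on this read-out higher numbers stand for weaker inhibition and lower numbers for stronger inhibition:
- compound 1, `Nc1nc(N2CCN(C(=O)COc3ccc(Cl)cc3)CC2)c2nc(-c3ccc(F)cc3)sc2n1`: 490 nM
- compound 2, `Nc1nc(N2CCN(C(=O)COc3ccc(Cl)cc3)CC2)c2nc(CCCCc3ccc(F)cc3)sc2n1`: 920 nM
- compound 3, `CCCCCc1nc2c(N3CCN(C(=O)COc4ccc(Cl)cc4)CC3)nc(N)nc2s1`: 690 nM

All three share the same core and differ only in the group on the aromatic carbon of the five-membered ring. Compound 3 gives the second highest of the three numbers; its nearest neighbour is compound 2 and its furthest is compound 1, and both gaps lie within the scatter. Indeed every measured step here falls within the scatter: a 1.9-fold higher number from compound 1 to compound 2 (0.27 log units; within the scatter), a 1.4-fold higher number from compound 1 to compound 3 (0.15 log units; within the scatter) and a 1.3-fold lower number from compound 2 to compound 3 (0.12 log units; within the scatter).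

Compound 4, `Cc1ccc(-c2nc3c(N4CCN(C(=O)COc5ccc(Cl)cc5)CC4)nc(N)nc3s2)cc1`, has not yet been measured in this assay. It differs from compound 3 by 4-methylphenyl in place of pentyl on an aromatic carbon. The step that bears most directly on this change is the reverse of a 1.4-fold higher number from compound 1 to compound 3 (0.15 log units; within the scatter), where an aromatic ring on the same carbon gave a number within the scatter of the pentyl compound. Compound 1 also stands closest in structure to compound 4, with another six-membered aromatic ring in the same place.

The expectation is therefore a step of a 1.4-fold lower number from compound 3 to compound 4 (0.14 log units; within the scatter), which is no change beyond the scatter, leaning toward the value of compound 1. Compound 4 is estimated at 500 nM, with a range from 250 nM to 1000 nM.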

Compound 4, half-maximal inhibitory concentration: 350 nM
For compound 4 the middle estimate is 1.4-fold (0.15 log units) above the measured one; measured number inside the range.
By their numbers in this assay, from the lowest: compounds 4, 1, 3 and 2 (each within the scatter of the next, the first and the last beyond it).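

In this assay, the position on the aromatic carbon of the five-membered ring now gives its first step beyond the scatter, a 2.6-fold lower number from compound 2 to compound 4 (0.42 log units; beyond the scatter), a modest step with 4-methylphenyl in place of 4-(4-fluorophenyl)butyl. The change from a pentyl chain to 4-methylphenyl stays within the scatter at a 2.0-fold lower number from compound 3 to compound 4 (0.29 log units; within the scatter), and methyl in place of fluoro on the aromatic ring stays within it at a 1.4-fold lower number from compound 1 to compound 4 (0.15 log units; within the scatter), so this position tolerates both ring substituents without a readable change. Any aryl-over-chain pattern therefore rests on the single separated pair of compound 2 and compound 4, with compound 1 printed within the scatter of both chain compounds, and no measurement at hand accounts for that separation.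

Still open, from the compounds shown here alone, is how this carbon responds to a pyridyl ring, a shorter chain such as ethyl, or a chain ending in an amine or a carboxylic acid. Also open, going by these compounds, is whether a methoxy or a trifluoromethyl group on the phenyl ring would move the number beyond the scatter of compound 1 and compound 4.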